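Replacing the aryl group of an aroylhydrazone with pyridin-4-yl

A few compounds are considered here, and "the series" means these few. Any claim that something is new, unique, unknown or untested is made for them only; others in the source may bear on it.

Measured compounds:
Compound 1, `Cc1c(C(=O)N/N=C\c2c(O)cccc2Cl)oc2cccc(O)c12`: 18700 nM
Compound 2, `Cc1c(C(=O)N/N=C\c2cccc(F)c2O)oc2cccc(O)c12`: 12700 nM
Compound 3, `Cc1c(C(=O)N/N=C\c2cc(O)ccc2O)oc2cccc(O)c12`: 95500 nM

All three share one core and differ only in the aryl group on a carbon with a double bond to nitrogen. In a functional assay on PC-3 cells (Homo sapiens) for inhibition (on this read-out higher numbers stand for weaker inhibition and lower numbers for stronger inhibition), compound 3 gives the highest number of the three: a 5.1-fold higher number from compound 1 to compound 3 (0.71 log units; beyond the scatter) and a 7.5-fold higher number from compound 2 to compound 3 (0.88 log units; beyond the scatter), while a 1.5-fold lower number from compound 1 to compound 2 (0.17 log units; within the scatter). Compound 4, `Cc1c(C(=O)N/N=C\c2ccncc2)oc2cccc(O)c12`, carries pyridin-4-yl in place of 2,5-dihydroxyphenyl on a carbon with a double bond to nitrogen. Among the measured compounds shown here, no measured step removes the hydroxylated ring altogether; the measured steps only exchange substituents on it, and both steps into compound 3 went to higher numbers. They therefore bear on the step to compound 4 only loosely, and the expected direction is open. Since the ring that leaves brought the highest number measured, the estimate for compound 4 is placed near compound 3 with a wide range: compound 4 is expected to give 50000 nM in this assay, between 8000 nM and 300000 nM, which means an expected 1.9-fold lower number from compound 3 to compound 4 (0.28 log units; within the scatter) that is not confidently beyond the scatter.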

Compound 4, half-maximal inhibitory concentration: >= 40000 nM
Compound 4 gave a limit, no number; the forecaster's own chance of this, stated with the estimate: 30%; the middle value is on the limit's open side.
By their numbers in this assay, from the lowest: compounds 2 and 1 (each within the scatter of the next); then compound 3.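

In this assay compound 4 returns a limit and not a number: the limit of >= 40000 nM in this assay, at which 1 of the 4 values shown sits. Even so, the limit can be read against the two lowest numbers, with pyridin-4-yl giving an at least 3.1-fold higher number from compound 2 to compound 4 (0.49 log units; beyond the scatter) and an at least 2.1-fold higher number from compound 1 to compound 4 (0.33 log units; beyond the scatter), so the first compound shown without a hydroxylated ring at this place, on a carbon with a double bond to nitrogen, does not match the 3-fluoro-2-hydroxyphenyl and 2-chloro-6-hydroxyphenyl groups. Going by these compounds, the step from compound 3 to compound 4 cannot be read, so the order of the pyridin-4-yl and 2,5-dihydroxyphenyl groups stays unknown.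

With a single compound lacking the hydroxylated ring, the compounds shown do not separate the loss of the hydroxyl groups from the entry of the ring nitrogen, and they give no true number for pyridin-4-yl in this assay. An unsubstituted phenyl group and a 2-hydroxyphenyl group at the same place would be the direct comparisons, the first carrying neither hydroxyl nor ring nitrogen and the second a hydroxyl with no chlorine or fluorine.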